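The source may report more compounds than this note shows. Statements on the series, on what has been measured and on what is new or still open speak of the compounds shown alone.

Compound 1 `CCc1ccc(-n2c(CCc3c[nH]c4ccccc34)nnc2[C@H](NC(=O)c2ccccn2)c2c[nH]c3ccccc23)cc1` was tested in a functional assay on CHO cells for antagonist activity at growth hormone secretagogue receptor type 1 (Homo sapiens) (a lower number here means a stronger inhibitor, a higher number a weaker inhibitor), and gives 129 nM. Of the two numbers recorded so far this is the higher one, and its nearest neighbour is compound 2 `COc1ccc(Cn2c(CCc3c[nH]c4ccccc34)nnc2[C@H](NC(=O)c2ccccn2)c2c[nH]c3ccccc23)cc1`, which in this assay gives 102 nM. Going by the values given here, the single measured step, a 1.3-fold lower number from compound 1 to compound 2 (0.10 log units; within the scatter), changes the group on an aromatic nitrogen and leaves the amide end of the molecule untouched, so these two compounds cannot be told apart on potency.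

Compound 3 `CCc1ccc(-n2c(CCc3c[nH]c4ccccc34)nnc2[C@H](NC(=O)Cc2ccccn2)c2c[nH]c3ccccc23)cc1` differs from compound 1 at a different place: (pyridin-2-yl)methyl in place of pyridin-2-yl on a carbonyl carbon. A single carbon is thereby inserted between the ring and the carbonyl of the amide. Among the compounds with values here, no measured step touches this part of the structure, so the change from compound 1 to compound 2 does not bear on the question, and the expectation rests on the change itself, with wide uncertainty. The expected step is therefore a 1.7-fold higher number from compound 1 to compound 3 (0.23 log units; within the scatter), a modest weakening that may well fall within the scatter. For compound 3 the expected value in this assay is 220 nM, within a range from 60 nM to 800 nM.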

Compound 3, antagonist equilibrium constant: 34 nM
Beside the measured number, compound 3's estimate is 6.5-fold (0.81 log units) above it, outside the stated range (below it).
By their numbers in this assay, from the lowest: compound 3; then compounds 2 and 1 (each within the scatter of the next).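

The amide end of the molecule, untouched by the earlier pair, turns out to respond: in this assay, (pyridin-2-yl)methyl in place of pyridin-2-yl on the carbonyl carbon gives a 3.8-fold lower number from compound 1 to compound 3 (0.58 log units; beyond the scatter) and so a modestly stronger inhibitor, a step beyond the scatter, unlike the earlier change on the aromatic nitrogen. The two groups carry the same aromatic ring, with the same counts of hydrogen-bond donors and acceptors and no net charge, so the counted difference is one added carbon, which shows that even so small a change at this position can shift the result measurably. No measurement of any property is available here to explain this shift.

On these data alone, a single added carbon gives only one point, so it remains open whether a longer chain such as (pyridin-2-yl)ethyl would strengthen inhibition further or lose the gain. As far as these compounds go, it is also open whether the ring nitrogen takes part, which benzyl on the carbonyl carbon could test, and whether the gain would carry over to compound 2, with its 4-methoxybenzyl group.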